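The compounds below may be only part of what the source reports. "The series", "measured", "known", "first", "only" and "open" are said of these compounds alone.

Going by the values given here, compound 1 `COc1cccc(CNCCCNc2ccnc3cc(-c4ccc(C(F)(F)F)cc4)ccc23)c1O` is one of three compounds measured in a physicochemical assay for acid dissociation. In this assay compound 1 gives 9.47, compound 2 `FC(F)(F)c1ccc(-c2ccc3c(NCCCNCc4ccco4)ccnc3c2)cc1` gives 9.47 and compound 3 `COc1ccc(F)cc1CNCCCNc1ccnc2cc(-c3cccc4ccccc34)ccc12` gives 9.47, so compound 1 stands level with both at the digits shown, within the scatter. Among the compounds with values here, the only measured step between two compounds that differ in a single place, from compound 1 to compound 2, is no change at the digits printed from compound 1 to compound 2 (within the scatter), where furan-2-yl replaces 2-hydroxy-3-methoxyphenyl on a saturated chain carbon bound to an amine nitrogen.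

Compound 4 `COc1cccc(CNCCCNc2ccnc3cc(Cc4ccc(F)cc4Cl)ccc23)c1O` has not yet been measured. It differs from compound 1 thus: 2-chloro-4-fluorobenzyl in place of 4-(trifluoromethyl)phenyl on an aromatic carbon. Within the data shown here, no measured step touches this part of the shared core, so the only guide is the one measured step, which lay within the scatter, and the three measured values, which are level. For compound 4 the step is therefore expected to be no change at the digits printed from compound 1 to compound 4 (within the scatter), nothing beyond the scatter. For compound 4 the value is estimated at 9.47, between 9.1 and 9.8.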

Compound 4, acid dissociation constant: 9.47
The estimate for compound 4 equals the measured number at the digits printed; the measured number falls inside the stated range.
By their numbers in this assay, from the lowest: compounds 1, 2, 3 and 4 (each within the scatter of the next).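

In this assay, the change at this aromatic carbon of the shared core gives no change at the digits printed from compound 1 to compound 4 (within the scatter) and so adds a second step that lies within the scatter. The earlier step changed only the group on a saturated chain carbon bound to an amine nitrogen, whereas this one replaces 4-(trifluoromethyl)phenyl, with 10 heavy atoms, by 2-chloro-4-fluorobenzyl, with 9 heavy atoms including a chlorine, and leaves the read-out unmoved at this position. No measurement is at hand that would explain this result.

The compounds shown leave open whether a group of another kind on this aromatic carbon, such as a primary amine or a carboxylic acid, would also stay within the scatter. They also leave open how a longer chain between the two amine nitrogens would read in this assay.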